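Swapping the Amide Substituent for a Piperidine Ring

The source may hold more compounds than are shown below. What is called first, only, known or untested is meant among the compounds shown, and "the series" means these compounds.

Of the compounds shown here, three sharing one core have been tested in a functional assay on the whole organism (strain Wistar) for inhibition, with Rattus norvegicus as the target, read by paw edema, with stated times of 60 min and 4 h, at a dose of 100 mg/kg by the oral route; on this read-out lower numbers stand for less inhibition and higher numbers for more inhibition at the one dose given (going by the name of the read-out). Compound 1 `COc1cc2c(cc1OC)C(CC(=O)N(C)C)CC2` gives 35.9%, compound 2 `COc1cc2c(cc1OC)C(CC(=O)NC(C)C)CC2` gives 39.1%, and compound 3 `COc1cc2c(cc1OC)C(CC(=O)NC(C)(C)C)CC2` gives 32.8%, the lowest of the three numbers shown, though within the usual scatter of both others. Compound 4 `COc1cc2c(cc1OC)C(CC(=O)N1CCCCC1)CC2` differs from compound 3 in one place: piperidin-1-yl in place of (tert-butyl)amino on a carbonyl carbon. The earlier changes at the same carbonyl carbon, a number 3.1 percentage points lower from compound 1 to compound 3 (within the scatter) and a number 6.3 percentage points lower from compound 2 to compound 3 (within the scatter), both stayed within the scatter, so no step beyond the scatter is expected in this assay for this change either; the expected step is a number 2.2 percentage points higher from compound 3 to compound 4 (within the scatter). For compound 4 the estimated value is 35%, with an expected range from 24% to 46%.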

Compound 4, a percentage reported as inhibition, in the whole organism at one dose (the size of the read-out at that dose, not a potency): 32%
Compound 4: the middle estimate sits 3 percentage points above what was measured; low and high end bracket the measured number.
By their numbers in this assay, from the lowest: compounds 4, 3, 1 and 2 (each within the scatter of the next).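

In this assay the piperidin-1-yl ring on the carbonyl carbon gives a number 0.8 percentage points lower from compound 3 to compound 4 (within the scatter) and a number 7.1 percentage points lower from compound 2 to compound 4 (within the scatter) and a number 3.9 percentage points lower from compound 1 to compound 4 (within the scatter). So a ring, which carries no hydrogen-bond donor where (tert-butyl)amino carries one, sets compound 4 apart from none of the three open-chain amides at this one dose. No measurement shown gives a reason for this result. Still open, going by these compounds, is whether morpholin-4-yl, benzylamino or a free carboxylic acid at this carbon would give a step beyond the scatter.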